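This account rests on a few compounds, and the source may have more. Where it says the series, first, only, none or still open, it means among the compounds named here.

Three compounds share one core and differ in a single group attached to it. Compound 1 `CC1=NC(C)=C(C(=O)O)C(c2ccc([N+](=O)[O-])cc2)/C1=C(\O)OC/C=C/c1ccccc1` gives 21000 nM in a functional assay on IMR-32 cells for inhibition of Voltage-dependent N-type calcium channel subunit alpha-1B (Homo sapiens), read by calcium flux; a lower number here means a stronger inhibitor, a higher number a weaker inhibitor. Compound 2 `CC1=NC(C)=C(C(=O)O)C(c2cccc(Cl)c2)/C1=C(\O)OC/C=C/c1ccccc1` gives 1000 nM in this assay, and compound 3 `CC1=NC(C)=C(C(=O)O)C(c2ccsc2)/C1=C(\O)OC/C=C/c1ccccc1` gives 2900 nM. Compound 2 stands at the lowest number of the three, and all of its steps lie beyond the scatter: a 21-fold lower number from compound 1 to compound 2 (1.32 log units; beyond the scatter), a 7.2-fold lower number from compound 1 to compound 3 (0.86 log units; beyond the scatter) and a 2.9-fold higher number from compound 2 to compound 3 (0.46 log units; beyond the scatter). Compound 4 `CC1=NC(C)=C(C(=O)O)C(c2cccc(Cl)c2)/C1=C(\O)OC/C=C/C1CCCCC1` has not yet been measured. It differs from compound 2 in another part of the molecule: cyclohexyl in place of phenyl on a double-bonded chain carbon bound to a double-bonded chain carbon. For the measured compounds named here, no measured step touches that part; all three change a different group, so none of them bears directly on this change. Going by the values given here, they show only that swapping one ring for another can move the number by more than the scatter. With nothing measured at this place, a step within or just beyond the scatter is expected, in no particular direction. The expected step is a 1.2-fold higher number from compound 2 to compound 4 (0.08 log units; within the scatter). Compound 4 is estimated at 1200 nM, with a range from 350 nM to 4500 nM.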

Compound 4, half-maximal inhibitory concentration: 830 nM
Estimate against measurement, compound 4: 1.4-fold (0.16 log units) above; measured number inside the range.
By their numbers in this assay, from the lowest: compounds 4 and 2 (each within the scatter of the next); then compound 3; then compound 1.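

Putting cyclohexyl in place of phenyl at the end of the chain gives a 1.2-fold lower number from compound 2 to compound 4 (0.08 log units; within the scatter), so compound 2 and compound 4 cannot be told apart in this assay. With 3-chlorophenyl on the saturated ring carbon, an aromatic ring at this place is therefore not needed for this level of inhibition, since a non-aromatic ring of six carbons does just as well. No measurement shown here explains why the two rings match.

On these data alone, it remains open whether a smaller ring such as cyclopropyl, a piperidine ring with its amine, or an open propyl chain would hold the number at this place. As far as these compounds go, it is also open whether the match between cyclohexyl and phenyl carries over when thiophen-3-yl or 4-nitrophenyl sits on the saturated ring carbon.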